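The source may report more compounds than this note shows. Statements on the series, on what has been measured and on what is new or still open speak of the compounds shown alone.

Measured compounds and their readings:
compound 1 `CN(C)c1ccc(/C=C/C=C/C(=O)N2CCCCC2)cc1` gives 13.4% in an assay for inhibition of Polyunsaturated fatty acid 5-lipoxygenase (Homo sapiens), read by spectrophotometry, tested at 20 uM; on this read-out lower numbers stand for less inhibition and higher numbers for more inhibition at the one concentration tested (going by the name of the read-out)
compound 2 `COc1cc(/C=C/C=C/C(=O)N2CCCCC2)cc(OC)c1O` gives 32.7% in this assay
compound 3 `O=C(/C=C/C=C/c1cc(O)c(O)c(O)c1)N1CCCCC1` gives 82.5% in this assay

Among these three, compound 1 stands lowest. Its nearest neighbour is compound 2, whose reading lies higher by an amount beyond the usual scatter, and compound 3 stands furthest away, higher still and also well beyond the scatter. The shared core, the piperidine amide on a doubly unsaturated chain, is the same in all three; what differs is the set of substituents on the six-membered aromatic ring of carbon only.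

Compound 4 `COc1ccc(/C=C/C=C/C(=O)N2CCCCC2)cc1` has not yet been measured. It differs from compound 1 in one place: methoxy in place of dimethylamino on an aromatic carbon. No step between two measured compounds isolates this change, so its size can only be guessed from the spread shown. Both compound 1 and compound 4 carry a single substituent on that ring with one hydrogen-bond acceptor and no donor, so the expected step from compound 1 to compound 4 in this assay is small, a number 1.6 percentage points higher from compound 1 to compound 4 (within the scatter), not beyond the scatter. Compound 4 is therefore estimated at 15%, within a range from 3% to 32%.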

Compound 4, a percentage reported as inhibition, at one concentration (the size of the read-out at that concentration, not a potency): 42.6%
The estimate for compound 4 lay 27.6 percentage points below the measured number; the whole stated range lies below it.
By their numbers in this assay, from the lowest: compound 1; then compounds 2 and 4 (each within the scatter of the next); then compound 3.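

Among the compounds shown here, replacing dimethylamino with methoxy on an aromatic carbon para to a large group gives a number 29.2 percentage points higher from compound 1 to compound 4 (beyond the scatter) in this assay, and this is the first step that isolates a single place, showing that readings here respond to the identity of this one substituent. The result also shows that matching counts do not guarantee matching readings at this position: the two groups have no ring, no net charge, no hydrogen-bond donors and one hydrogen-bond acceptor each, yet the step lies beyond the scatter. Nothing shown explains why the exchange of these two groups moves the reading, so its cause remains unknown.

The compounds shown leave open whether the step follows the oxygen itself or the loss of a carbon, which a hydroxy, ethoxy, amino or methylamino group at this same place could begin to separate. Compounds 2 and 3 differ from compound 4 in more than one place, so the contribution of each extra ring substituent cannot be read from them, and a single-hydroxy analogue would be the nearest link.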